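The source may hold more compounds than are shown below. What is called first, only, known or untested is meant among the compounds shown, and "the series" means these compounds.

Among the compounds with values here, compound 2 `Clc1cncc(N2CCNCC2)c1` gives 309 nM in an assay on HEK293 cells for displacement of a labelled ligand from Neuronal acetylcholine receptor; alpha4/beta2 (Homo sapiens) (a lower number here means a stronger inhibitor, a higher number a weaker inhibitor), the higher of the two numbers so far, though within the scatter of compound 1 `C=COc1cncc(N2CCNCC2)c1`, which in this assay gives 191 nM. Within the data shown here, the single measured step, a 1.6-fold higher number from compound 1 to compound 2 (0.21 log units; within the scatter), concerns chloro in place of vinyloxy on an aromatic carbon. Compound 3 `Cc1ncc(N2CCNCC2)cc1Cl` differs from compound 2 by methyl in place of hydrogen on an aromatic carbon. Among the measured compounds shown here, no measured step covers a methyl entering, so nothing here bears directly on this change, and the one step available gives no direction. The step of a 1.0-fold lower number from compound 2 to compound 3 (0.01 log units; within the scatter) is therefore expected to stay within the scatter. Compound 3 is estimated at 300 nM, with a range of 100 nM to 900 nM.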

Compound 3, half-maximal inhibitory concentration: 525 nM
For compound 3 the middle estimate is 1.8-fold (0.24 log units) below the measured one, within the range that was stated.
By their numbers in this assay, from the lowest: compounds 1, 2 and 3 (each within the scatter of the next, the first and the last beyond it).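

In this assay, methyl on the aromatic carbon next to the ring nitrogen and ortho to the chloro group gives a 1.7-fold higher number from compound 2 to compound 3 (0.23 log units; within the scatter), a step within the scatter. Within the data shown here, this is the first reading at this position, as the earlier step concerned only the exchange of vinyloxy and chloro. No available evidence accounts for the size of this step. On these data alone, whether ethyl, methoxy or an amine at this position would also stay within the scatter remains open. Also open, as far as these compounds go, is whether methyl gives a similar step with vinyloxy in place of chloro.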